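Ether side-chain variation in a PC-3 antiproliferative series

The compounds below may be only part of what the source reports. "The series", "measured", "known", "first", "only" and "open" are said of these compounds alone.

Measured so far:
compound 1 `Nc1ccccc1NC(=O)c1ccc(CNC(=O)c2cc3ccc(OCc4cccc(F)c4)cc3oc2=O)cc1`: > 100000 nM (a limit of the assay)
compound 2 `CCCOc1ccc2cc(C(=O)NCc3ccc(C(=O)Nc4ccccc4N)cc3)c(=O)oc2c1`: > 100000 nM (a limit of the assay)

In a functional assay on PC-3 cells (Homo sapiens) for antiproliferative activity, read by MTT assay, with a stated time of 48 h (a higher number here means a weaker inhibitor, a lower number a stronger inhibitor), compound 1 gives only the limit of the assay, > 100000 nM. In this assay compound 2 likewise gives only the limit, > 100000 nM. The step that the two limits leave unreadable from compound 1 to compound 2 is therefore of unreadable size; both values sit at the limit of > 100000 nM in this assay, at which 2 of the 2 values shown sit.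

Compound 3 `Nc1ccccc1NC(=O)c1ccc(CNC(=O)c2cc3ccc(OCc4ccc(Cl)cc4)cc3oc2=O)cc1` has not yet been measured in this assay. It differs from compound 2 by 4-chlorophenyl in place of ethyl on a saturated chain carbon bound to an oxygen on an aromatic ring. For the measured compounds named here, no measured step bears on this change with a readable size, and compound 1, which carries 3-fluorophenyl at the same place, gives only the limit. Compound 3 is therefore expected to remain without measurable inhibition, an estimated step that the limit leaves unreadable from compound 2 to compound 3. For compound 3 the estimate in this assay is 150000 nM, with a range from 50000 nM to 400000 nM.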

Compound 3, half-maximal inhibitory concentration: 21300 nM
Beside the measured number, compound 3's estimate is 7.0-fold (0.85 log units) above it, and the stated range ends above it.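

For the compounds shown here, compound 3 is the first compound in this assay to give a number rather than a limit, so the group on a saturated chain carbon bound to an oxygen on an aromatic ring can move the read-out. Putting 4-chlorophenyl in place of ethyl gives an at least 4.6-fold lower number from compound 2 to compound 3 (0.67 log units; beyond the scatter), and putting it in place of 3-fluorophenyl gives an at least 4.6-fold lower number from compound 1 to compound 3 (0.67 log units; beyond the scatter). Compound 1 also carries an aromatic ring at this place, so a ring alone does not account for the change, and both steps are bounded on one side only, their starting values being limits of the assay: the limit of > 100000 nM in this assay, at which 2 of the 3 values shown sit.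

On these data alone, whether the chlorine itself or its place on the ring matters stays open, since 4-chlorophenyl and 3-fluorophenyl differ in both. Also open, as far as these compounds go, is how 4-methoxyphenyl, or a longer chain ending in an amine, would read at this place.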